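The source may hold more compounds than are shown below. What is called first, only, known or untested is meant among the compounds shown, and "the series" means these compounds.

Compounds measured so far:
Compound 1 `COc1ccc(-c2cc(COC(Cc3cn(C4CCN(Cc5ccc([N+](=O)[O-])cc5)CC4)nn3)c3ccc(Br)cc3)on2)cc1`: in a functional assay on MDA-MB-231 cells (Homo sapiens) for cytotoxicity, with a stated time of 48 h (on this read-out lower numbers stand for stronger inhibition and higher numbers for weaker inhibition), compound 1 reaches only the limit > 25000 nM.
Compound 2 `O=[N+]([O-])c1ccc(CN2CCC(n3cc(CC(OCc4cc(-c5cccc(F)c5)no4)c4ccc(Br)cc4)nn3)CC2)cc1`: compound 2 gives 5000 nM.
Compound 3 `COc1cccc(-c2cc(COC(Cc3cn(C4CCN(Cc5ccc([N+](=O)[O-])cc5)CC4)nn3)c3ccc(Br)cc3)on2)c1`: compound 3 reaches only the limit > 25000 nM.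

Compound 1 stands at the limit, so only a limit is known for it, and the same holds for compound 3, in keeping with the limit of > 25000 nM in this assay, at which 2 of the 3 values shown sit. The one readable step among these three runs an at least 5.0-fold lower number from compound 1 to compound 2 (0.69 log units; beyond the scatter). The step that the two limits leave unreadable from compound 1 to compound 3, whereas an at least 5.0-fold higher number from compound 2 to compound 3 (0.69 log units; beyond the scatter).

Compound 4 `N#Cc1cccc(-c2cc(COC(Cc3cn(C4CCN(Cc5ccc([N+](=O)[O-])cc5)CC4)nn3)c3ccc(Br)cc3)on2)c1` differs from compound 1 in one place: 3-cyanophenyl in place of 4-methoxyphenyl on an aromatic carbon. The step from compound 1 to compound 2 bears on this, since both replace the 4-methoxyphenyl with a group bearing a substituent at the 3-position of the phenyl; the step from compound 1 to compound 3 shows that such a substituent does not always bring the number below the limit. A nitrile has not been tried here, so the expectation is broad. Compound 4 is estimated at 12000 nM, within a range of 3000 nM to 40000 nM. This estimate corresponds to an expected step of an at least 2.0-fold lower number from compound 1 to compound 4 (0.31 log units; beyond the scatter), with a real chance that only a limit is reported.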

Compound 4, half-maximal inhibitory concentration: > 25000 nM
Compound 4 ended at the assay's limit (the forecaster's own chance of this, stated with the estimate: 50%); middle value at least 2.0-fold (0.31 log units) from the limit.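

In this assay, cyano in place of fluoro gives an at least 5.0-fold higher number from compound 2 to compound 4 (0.69 log units; beyond the scatter), so 3-cyanophenyl, like 3-methoxyphenyl in compound 3, does not keep the measurable value of compound 2. Among the groups shown on this aromatic carbon next to the ring nitrogen, a substituent at that place on the phenyl is therefore not enough on its own: of 3-fluorophenyl, 3-methoxyphenyl and 3-cyanophenyl, only 3-fluorophenyl gives a number rather than a limit. The steps among compound 1, compound 3 and compound 4 cannot be read, since each pair joins two limits: the limit of > 25000 nM in this assay, at which 3 of the 4 values shown sit.

On these data alone, whether 3-chlorophenyl or an unsubstituted phenyl at this place would give a value like that of compound 2 remains open. So does whether 4-fluorophenyl would match 3-fluorophenyl, which would separate the role of the fluoro from that of its place on the ring.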